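Side-chain change from compound 2 to compound 3

This account rests on a few compounds, and the source may have more. Where it says the series, first, only, none or still open, it means among the compounds named here.

Among the compounds with values here, in a functional assay on SMMC-7721 cells (Homo sapiens) for antiproliferative activity, read by MTT assay, with a stated time of 48 h (a higher number here means a weaker inhibitor, a lower number a stronger inhibitor), compound 2 (`COCOC/C1=C/C[C@](C)(CCC=C(C)C)/C=C/[C@@H](OC(=O)C=C(C)C)[C@](C)(O)/C=C/C1=O`) gives 3250 nM, the higher of the two numbers so far. Within the data shown here, the only other measured compound, compound 1 (`CC(C)=CCC[C@]1(C)/C=C/[C@@H](OC(=O)C=C(C)C)[C@](C)(O)/C=C/C(=O)/C(CN(C(C)C)C(C)C)=C\C1`), gives 340 nM. Compound 3 (`CC(C)=CCC[C@]1(C)/C=C/[C@@H](OC(=O)C=C(C)C)[C@](C)(O)/C=C/C(=O)/C(Cn2cc(CO)nn2)=C\C1`) carries 4-(hydroxymethyl)-1H-1,2,3-triazol-1-yl in place of methoxymethoxy on a saturated chain carbon bound to a double-bonded ring carbon. Among the measured compounds shown here, one measured step bears on this place: a 9.6-fold higher number from compound 1 to compound 2 (0.98 log units; beyond the scatter), a modest step beyond the scatter, with methoxymethoxy in place of diisopropylamino. For the measured compounds named here, it shows that a change here can shift the number, but no compound with the entering group has been measured, so the direction remains uncertain. A smaller step towards a lower number is expected in this assay. The expected step is a 1.8-fold lower number from compound 2 to compound 3 (0.26 log units; within the scatter). For compound 3 the estimated value is 1800 nM, within a range of 500 nM to 6500 nM.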

Compound 3, half-maximal inhibitory concentration: 3560 nM
The estimate for compound 3 lay 2.0-fold (0.30 log units) below the measured number, and the stated range covers the measured number.
By their numbers in this assay, from the lowest: compound 1; then compounds 2 and 3 (each within the scatter of the next).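

In this assay, 4-(hydroxymethyl)-1H-1,2,3-triazol-1-yl in place of methoxymethoxy gives a 1.1-fold higher number from compound 2 to compound 3 (0.04 log units; within the scatter) so at this saturated chain carbon a group with a five-membered aromatic ring and a group with no ring read alike. With diisopropylamino as the group replaced, the same entering group gives a 10-fold higher number from compound 1 to compound 3 (1.02 log units; beyond the scatter) which is close in size to a 9.6-fold higher number from compound 1 to compound 2 (0.98 log units; beyond the scatter) and leaves compound 1 apart from the other two compounds. Among these three compounds, only the one with diisopropylamino has the lower number, and two quite different non-amine groups share the higher one.

From the compounds shown here alone, whether the lower number extends to other amines, such as dimethylamino or a piperidine ring, remains open, as does the effect of a carboxylic acid at this place. No available evidence bears on the reason for these readings.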